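A Phenoxy for a Benzyl on the Shared Core

The source may report more compounds than this note shows. Statements on the series, on what has been measured and on what is new or still open speak of the compounds shown alone.

Of the compounds shown here, three have been measured, and they sit level with one another. Compound 1 `COc1ccc(F)cc1CNCCCNc1ccnc2cc(CC(C)C)ccc12`, compound 2 `COc1ccc(F)cc1CNCCCNc1ccnc2cc(Cc3ccc(F)cc3)ccc12` and compound 3 `COc1cccc(CNCCCNc2ccnc3cc(Cc4ccc(F)cc4)ccc23)c1O` share a core and differ only in their outer groups. In an ADME assay for permeability, using PAMPA, with a stated time of 30 min, at pH 7.4 (on this read-out lower numbers stand for lower permeability and higher numbers for higher permeability), compound 1 gives 23 10^-6 cm/s, compound 2 gives 23 10^-6 cm/s and compound 3 gives 23 10^-6 cm/s. The step of no change at the digits printed from compound 1 to compound 2 (within the scatter) and the step of no change at the digits printed from compound 2 to compound 3 (within the scatter) both stayed within the scatter, so neither the 4-fluorophenyl in place of isopropyl nor the 2-hydroxy-3-methoxyphenyl in place of 5-fluoro-2-methoxyphenyl moved the read-out.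

Compound 4 `COc1ccc(F)cc1CNCCCNc1ccnc2cc(Oc3ccc(F)cc3)ccc12` has not yet been measured. It differs from compound 2 in one place: 4-fluorophenoxy in place of 4-fluorobenzyl on an aromatic carbon. The change adds one hydrogen-bond acceptor while keeping the heavy-atom count and the single aromatic ring.

Within the data shown here, no measured step bears directly on a phenoxy for a benzyl, and the two measured steps, each within the scatter, give no sign of movement in this assay. Compound 4 is therefore expected to stay close to compound 2, with the step of a 1.2-fold lower number from compound 2 to compound 4 (0.06 log units; within the scatter) estimated to lie within the scatter. Compound 4 is estimated at 20 10^-6 cm/s, between 10 10^-6 cm/s and 40 10^-6 cm/s.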

Compound 4, apparent permeability: 317 10^-6 cm/s
Estimate against measurement, compound 4: 16-fold (1.20 log units) below; the measured number lies above the stated range.
By their numbers in this assay, from the lowest: compounds 1, 2 and 3 (each within the scatter of the next); then compound 4.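

In this assay, the position on the aromatic carbon proved far from silent: 4-fluorophenoxy in place of 4-fluorobenzyl gave a 14-fold higher number from compound 2 to compound 4 (1.14 log units; beyond the scatter) and 4-fluorophenoxy in place of isobutyl gave a 14-fold higher number from compound 1 to compound 4 (1.14 log units; beyond the scatter) in the same read-out. The earlier exchange at this carbon, no change at the digits printed from compound 1 to compound 2 (within the scatter) had suggested that the read-out did not respond to the group placed there, but among these compounds the two groups attached through carbon sit level, while the one attached through oxygen stands well apart, even though the 4-fluorobenzyl and 4-fluorophenoxy groups have the same heavy-atom count and a single aromatic ring each. Nothing beyond these read-outs is available to explain the size of the rise.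

The compounds shown leave open whether the rise belongs to the oxygen attachment in general or only to this oxygen together with its 4-fluorophenyl ring, a question that an unsubstituted phenoxy, an isobutoxy, a sulfur-linked 4-fluorophenyl or an amine-linked 4-fluorophenyl group at the same carbon would address. They also leave open whether the rise would carry over to the 2-hydroxy-3-methoxyphenyl side of compound 3.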